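The compounds below may be only part of what the source reports. "The series", "measured", "known", "first", "only" and "open" are said of these compounds alone.

Measured so far in a functional assay on HT-29 cells (Homo sapiens) for cytotoxicity, read by MTT assay, with a stated time of 72 h; a lower number here means a stronger inhibitor, a higher number a weaker inhibitor:
- compound 1 `COc1ccc(C(=O)c2cc(OC)c(OC)c(OC)c2)cc1NC(=O)/C=C/c1ccc(OC)c(OC)c1` gives 2500 nM
- compound 2 `COc1ccc(/C=C/C(=O)Nc2cc(C(=O)c3cc(OC)c(OC)c(OC)c3)ccc2OC)cc1` gives 5010 nM
- compound 3 `COc1cccc(/C=C/C(=O)Nc2cc(C(=O)c3cc(OC)c(OC)c(OC)c3)ccc2OC)c1` gives 1900 nM

All three share one core and differ only in the aromatic ring at the end of the amide-linked chain. Compound 3 carries the lowest of the three numbers in this assay, but its gap to compound 1 is within the scatter, so the two cannot be ranked; only compound 2 stands apart, with a 2.6-fold lower number from compound 2 to compound 3 (0.42 log units; beyond the scatter).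

Compound 4 `COc1ccc(C(=O)c2cc(OC)c(OC)c(OC)c2)cc1NC(=O)/C=C/c1ccc(N)cc1` changes that same ring: 4-aminophenyl in place of 3-methoxyphenyl on a double-bonded chain carbon bound to a double-bonded chain carbon. Going by the values given here, three measured steps touch this region. The step of a 2.0-fold higher number from compound 1 to compound 2 (0.30 log units; within the scatter) and the step of a 1.3-fold lower number from compound 1 to compound 3 (0.12 log units; within the scatter) both remove a methoxy from the ring and stay within the scatter. The step of a 2.6-fold lower number from compound 2 to compound 3 (0.42 log units; beyond the scatter) moves the methoxy from the 4-position to the 3-position and is modest but beyond the scatter. Compound 4 returns to a 4-substituted ring, now with an amino group, so a modest move back toward the number of compound 2 is expected, though the amino group is new to this set and nothing measured here speaks to it directly.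

The expected step is a 1.8-fold higher number from compound 3 to compound 4 (0.27 log units; within the scatter). For compound 4 the estimate in this assay is 3500 nM, with a range from 1200 nM to 10000 nM.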

Compound 4, half-maximal inhibitory concentration: 5600 nM
Compound 4: middle estimate off by 1.6-fold (0.20 log units), on the low side, and the stated range covers the measured number.
By their numbers in this assay, from the lowest: compounds 3, 1, 2 and 4 (each within the scatter of the next, the first and the last beyond it).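

In this assay, replacing either the 3-methoxyphenyl of compound 3 or the 3,4-dimethoxyphenyl of compound 1 with 4-aminophenyl raises the number by a modest step (a 2.9-fold higher number from compound 3 to compound 4 (0.47 log units; beyond the scatter); a 2.2-fold higher number from compound 1 to compound 4 (0.35 log units; beyond the scatter)). Amino in place of methoxy on the 4-substituted ring, by contrast, leaves the result within the scatter (a 1.1-fold higher number from compound 2 to compound 4 (0.05 log units; within the scatter)), so compound 2 and compound 4 cannot be ranked, and this is the first sign that this end of the molecule can accept a nitrogen group in place of an oxygen group without a readable change. Compound 2 and compound 4, each with a single group at the 4-position of the ring, now both give higher numbers than compound 3, although compound 1 goes against any simple rule: it also carries a 4-methoxy group, yet its gap to compound 3 is within the scatter.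

No measurement here explains why these numbers differ. As far as these compounds go, it remains open whether the ring's substitution pattern or the group itself matters more, a question that 3-aminophenyl could test, and whether 4-hydroxyphenyl or an unsubstituted phenyl would give a number closer to compound 3 or compound 4.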